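Hydrogen in place of methyl on compound 1

A few compounds are considered here, and "the series" means these few. Any claim that something is new, unique, unknown or untested is made for them only; others in the source may bear on it.

In a functional assay on cells (Tumor Cell line, Homo sapiens) for cytotoxicity (on this read-out higher numbers stand for weaker inhibition of growth and lower numbers for stronger inhibition of growth), compound 1 (`Cc1cc(C)c2c(O)cc(-c3ccc(Cl)cc3)nc2n1`) gives 19500 nM and compound 2 (`COc1ccc(-c2cc(O)c3c(C)cc(C)nc3n2)cc1`) gives 33100 nM within the scatter of each other. Within the data shown here, the only measured step (a 1.7-fold higher number from compound 1 to compound 2 (0.23 log units; within the scatter)) is methoxy in place of chloro on an aromatic carbon and does not test the present change. Compound 3 (`Cc1ccnc2nc(-c3ccc(Cl)cc3)cc(O)c12`) carries hydrogen in place of methyl on an aromatic carbon next to the ring nitrogen (hydrogen in place of methyl on an aromatic carbon). With so little data, no step beyond the scatter is expected in this assay and no direction can be assigned. The estimate means a 1.1-fold higher number from compound 1 to compound 3 (0.03 log units; within the scatter) as the expected step. For compound 3 the expected value is 21000 nM with an estimated range from 9000 nM to 50000 nM as its span.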

Compound 3, concentration for 50% growth inhibition: 5130 nM
The estimate for compound 3 lay 4.1-fold (0.61 log units) above the measured number; measured number outside the range, below it.
By their numbers in this assay, from the lowest: compound 3; then compounds 1 and 2 (each within the scatter of the next).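

Hydrogen on the aromatic carbon next to the ring nitrogen gives the first step in the series beyond the scatter: in this assay the change means a 3.8-fold lower number from compound 1 to compound 3 (0.58 log units; beyond the scatter) and so this position, unlike the chloro-to-methoxy exchange, moves the read-out. The methyl there is not required for growth inhibition on the core of compound 1. Nothing available explains the shift.

Open, from the compounds shown here alone, is whether an ethyl group or an amine at this carbon would keep the lower number. Also open, going by these compounds, is whether removing this methyl has the same effect alongside the methoxy of compound 2.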